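This account rests on a few compounds, and the source may have more. Where it says the series, first, only, none or still open, it means among the compounds named here.

Compound 2 `CCCCOc1ccc(-c2nc3c(=O)n(C)c(=O)n(C)c3[nH]2)cc1` carries a butoxy group on a six-membered aromatic ring of carbon only, attached to the shared core. Within the data shown here, in an assay for binding affinity to adenosine receptor A1 (Bos taurus) (a higher number here means a weaker inhibitor, a lower number a stronger inhibitor), compound 2 gives 4 nM, the highest of the two numbers measured so far. Its nearest neighbour is compound 1 `Cn1c(=O)c2nc(-c3ccc(I)cc3)[nH]c2n(C)c1=O`, which in this assay gives 1.3 nM; putting butoxy in place of iodo on an aromatic carbon brings a 3.1-fold higher number from compound 1 to compound 2 (0.49 log units; beyond the scatter). Compound 3 `Cn1c(=O)c2nc(-c3ccc([N+](=O)[O-])cc3)[nH]c2n(C)c1=O` has not been measured; it differs from compound 2 by nitro in place of butoxy on an aromatic carbon. Among the measured compounds shown here, the only measured step that bears on this change is the swap at the same aromatic carbon from compound 1 to compound 2, which was modest. A change of similar or smaller size is therefore expected, most likely a slightly lower number, a 1.3-fold lower number from compound 2 to compound 3 (0.12 log units; within the scatter), though one still within the usual scatter. Compound 3 is estimated at 3 nM, in a range from 1 nM to 12 nM.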

Compound 3, half-maximal inhibitory concentration: 8 nM
Beside the measured number, compound 3's estimate is 2.7-fold (0.43 log units) below it; low and high end bracket the measured number.
By their numbers in this assay, from the lowest: compound 1; then compounds 2 and 3 (each within the scatter of the next).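

In this assay exchanging the butoxy group for a nitro group brings a 2.0-fold higher number from compound 2 to compound 3 (0.30 log units; within the scatter) and so does not separate these two quite different groups. Iodo, by contrast, now stands apart from both: nitro in place of iodo brings a 6.2-fold higher number from compound 1 to compound 3 (0.79 log units; beyond the scatter) and, with the earlier step to butoxy also beyond the scatter, leaves compound 1 the strongest inhibitor of the three. No measurement shown here explains why iodo differs from the other two groups.

On these data alone, it remains open whether bromo or chloro at this carbon would stay close to iodo, or whether the number would instead rise towards those of compound 2 and compound 3. An amine, a carboxylic acid or a shorter chain such as methoxy at this carbon also remains an open question.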